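A 1,3-benzoxazol-2-yl swap in the series

This account rests on a few compounds, and the source may have more. Where it says the series, first, only, none or still open, it means among the compounds named here.

In an ADME assay on HEK293 cells (Homo sapiens) for cytotoxicity, read by MTT assay, with a stated time of 48 h (a higher number here means a weaker inhibitor, a lower number a stronger inhibitor), compound 3 `CCN(CC)CCCCn1c(N)c(-c2nc3ccccc3[nH]2)c2nc(C#N)c(C#N)nc21` gives 5370 nM and holds the lower of the two actual numbers in the series. Compound 1 `CN1CCN(CCn2c(N)c(-c3nc4ccccc4[nH]3)c3nc(C#N)c(C#N)nc32)CC1` gives 10900 nM as the other. Compound 2 `CCCCn1c(N)c(-c2nc3ccccc3[nH]2)c2nc(C#N)c(C#N)nc21` gives > 50000 nM as a limit of the assay. The steps of an at least 9.3-fold lower number from compound 2 to compound 3 (0.96 log units; beyond the scatter) and a 2.0-fold lower number from compound 1 to compound 3 (0.31 log units; beyond the scatter) both concern the chain on the aromatic nitrogen. Compound 4 `CCN(CC)CCCCn1c(N)c(-c2nc3ccccc3o2)c2nc(C#N)c(C#N)nc21` keeps the 4-(diethylamino)butyl group and changes on an aromatic carbon: 1,3-benzoxazol-2-yl in place of 1H-benzimidazol-2-yl on an aromatic carbon in the structure. For the measured compounds named here, no measured step touches this place, so the expectation rests on compound 3 at 5370 nM and no step beyond the scatter is expected in this assay for this swap. The estimated change is a 1.1-fold higher number from compound 3 to compound 4 (0.05 log units; within the scatter) in this series. Compound 4 is estimated at 6000 nM with an expected range from 2000 nM to 18000 nM in this assay here.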

Compound 4, half-maximal inhibitory concentration: 3960 nM
The estimate for compound 4 lay 1.5-fold (0.18 log units) above the measured number; measured number inside the range.
By their numbers in this assay, from the lowest: compounds 4 and 3 (each within the scatter of the next); then compound 1. At a limit, above all of these: compound 2.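

In this assay, the swap gives a 1.4-fold lower number from compound 3 to compound 4 (0.13 log units; within the scatter), so this aromatic carbon accepts 1,3-benzoxazol-2-yl in place of 1H-benzimidazol-2-yl with no change beyond the scatter. The earlier steps shown here all concerned the chain on the aromatic nitrogen, whereas this one removes the hydrogen-bond donor of the entering group's predecessor and leaves the read-out within the scatter. Nothing at hand gives a cause for this result.

Going by these compounds, whether a 1,3-benzothiazol-2-yl or a plain phenyl group at this carbon would also stay within the scatter remains open. So does whether the swap reads the same with the chain of compound 1.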